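Chain extension on the hydroxyalkyl side chain of compound 2

The source may report more compounds than this note shows. Statements on the series, on what has been measured and on what is new or still open speak of the compounds shown alone.

Measured compounds:
compound 1, `O=c1ccc(CCCO)nn1Cc1ccccc1`, > 100000 nM
compound 2, `Cn1nc(CCO)ccc1=O`, > 100000 nM
compound 3, `O=c1ccc(CCOCc2ccccc2)nn1Cc1ccccc1`, 32300 nM

Compound 2 is known only as a limit in a functional assay on aorta (Rattus norvegicus); a lower number here means a stronger inhibitor, a higher number a weaker inhibitor. Its value > 100000 nM is the limit of the assay, not a number, and the same holds for compound 1, whose value > 100000 nM is also a limit. Compound 3 alone gives a number, 32300 nM, so that the limit of > 100000 nM in this assay, at which 2 of the 3 values shown sit, is where two of the three values stand.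

Compound 4, `Cn1nc(CCCO)ccc1=O`, has not yet been measured in this assay. It differs from compound 2 as follows: hydroxymethyl in place of hydroxy on a saturated chain carbon, two bonds along the chain from an aromatic carbon. Within the data shown here, the only measured step, an at least 3.0-fold lower number from compound 1 to compound 3 (0.49 log units; beyond the scatter), changes a different part of the side chain and does not describe the change from compound 2 to compound 4; it shows only that leaving the limit is possible when the chain carries a benzyloxy group. Compound 1, which carries the same 3-hydroxypropyl chain that compound 4 would carry, sits at the limit, and compound 2 sits at the limit too, so no movement beyond the scatter is expected, and the step that the limit leaves unreadable from compound 2 to compound 4 is estimated to be small. Compound 4 is therefore expected to give about 150000 nM, within 50000 nM to 500000 nM, most likely again as a limit.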

Compound 4, half-maximal inhibitory concentration: > 100000 nM
Compound 4: only a limit was reported; the forecaster's own chance of this, stated with the estimate: 85%; the middle value does not contradict the limit.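

Compound 4, like compound 1 and compound 2, is reported only as a limit in this assay, so the steps from compound 1 and compound 2 to compound 4 cannot be read: the limit of > 100000 nM in this assay, at which 3 of the 4 values shown sit. The compounds shown leave open whether the length of the hydroxyalkyl chain matters at all in this assay, with compound 3 the only one giving a number.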